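The source may hold more compounds than are shown below. What is called first, only, known or untested is meant among the compounds shown, and "the series" means these compounds.

Cytotoxicity series, read in a functional assay on Ehrlich cells (Mus musculus) for cytotoxicity, tested at 100 ug/mL; on this read-out higher numbers stand for a stronger effect at the one concentration tested and lower numbers for a weaker effect:

compound 1 `COc1cc(N2C(N)=C(C#N)C(c3ccc(O)cc3)C3=C2CC(C)(C)CC3=O)cc(OC)c1OC`: 100%
compound 2 `COc1cc(N2C(N)=C(C#N)C(/C=C/c3ccccc3)C3=C2CC(C)(C)CC3=O)cc(OC)c1OC`: 40%
compound 3 `COc1cc(N2C(N)=C(C#N)C(c3ccc(Cl)cc3Cl)C3=C2CC(C)(C)CC3=O)cc(OC)c1OC`: 100%

Compound 3 stands level with compound 1 at the digits printed, the two together the highest of the three numbers; no change at the digits printed from compound 1 to compound 3 (within the scatter). The only large move is a number 60 percentage points higher from compound 2 to compound 3 (beyond the scatter), which swaps out the 2-phenylethenyl group.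

Next step: compound 4 `COc1cc(N2C(N)=C(C#N)C(c3ccccc3O)C3=C2CC(C)(C)CC3=O)cc(OC)c1OC`, differing as 2-hydroxyphenyl in place of 2,4-dichlorophenyl on a saturated ring carbon. Among the measured compounds shown here, the step that bears on it is the one from compound 1 to compound 3, an exchange of one phenyl-type ring for another, and it was flat; the large steps both involve the 2-phenylethenyl group, which compound 4 does not carry. The expectation is therefore a number 5 percentage points lower from compound 3 to compound 4 (within the scatter), nothing beyond the scatter. Compound 4 is estimated at 95%, between 70% and 100%.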

Compound 4, a percentage reported as activity, at one concentration (the size of the read-out at that concentration, not a potency): 10%
Compound 4: the middle estimate sits 85 percentage points above what was measured; the measured number lies below the stated range.
By their numbers in this assay, from the lowest: compound 4; then compound 2; then compounds 1 and 3 (each within the scatter of the next).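

In this assay the aromatic group on the saturated ring carbon is not freely exchangeable: 2-hydroxyphenyl in place of 2,4-dichlorophenyl gives a number 90 percentage points lower from compound 3 to compound 4 (beyond the scatter) and 2-hydroxyphenyl in place of 4-hydroxyphenyl gives a number 90 percentage points lower from compound 1 to compound 4 (beyond the scatter). Between these two hydroxyphenyl groups, the place of the hydroxyl on the phenyl ring alone carries that step, and 2-phenylethenyl no longer marks the bottom of the series, with a number 30 percentage points lower from compound 2 to compound 4 (beyond the scatter). Nothing available explains the loss.

As far as these compounds go, whether a 3-hydroxyphenyl, 2-methoxyphenyl or 2-aminophenyl group at this carbon would keep the number of compound 1 or that of compound 4 stays open.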